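Nitro on the benzyloxy group against the assay limit

The compounds below may be only part of what the source reports. "The series", "measured", "known", "first", "only" and "open" are said of these compounds alone.

Compound 2 `c1ccc(COc2ccc(Nc3ncnc4cc5c(cc34)OCCOCCOCCOCCO5)cc2)cc1` carries a benzyloxy group and gives 29500 nM in a functional assay on A549 cells (Homo sapiens) for antiproliferative activity, read by MTT assay, with a stated time of 72 h; a lower number here means a stronger inhibitor, a higher number a weaker inhibitor. Compound 1 `O=[N+]([O-])c1ccc(COc2ccc(Nc3ncnc4cc5c(cc34)OCCOCCOCCOCCO5)cc2)cc1` is its (4-nitrobenzyl)oxy analogue. In this assay compound 1 returns only the assay limit, > 100000 nM. The change nitro in place of hydrogen on an aromatic carbon therefore produces an at least 3.3-fold higher number from compound 2 to compound 1 (0.53 log units; beyond the scatter). Compound 3 `c1ccc(COc2cccc(Nc3ncnc4cc5c(cc34)OCCOCCOCCO5)c2)cc1` differs from compound 2 in more than one place; the difference between the two cores is not broken down here. In this assay compound 3 likewise reaches only the assay limit, > 100000 nM. Compound 4 `O=[N+]([O-])c1ccc(COc2cccc(Nc3ncnc4cc5c(cc34)OCCOCCOCCO5)c2)cc1` is the nitro analogue of compound 3, the change being (nitro in place of hydrogen on an aromatic carbon), the same change as from compound 2 to compound 1 and at a place described in the same words. Two of the three measured values already sit at the limit of > 100000 nM in this assay, at which 2 of the 3 values shown sit, so there is little room for a counted step. Given that the earlier nitro step gave an at least 3.3-fold higher number from compound 2 to compound 1 (0.53 log units; beyond the scatter), compound 4 is expected to remain at or beyond the limit, the expected step being a step that the limit leaves unreadable from compound 3 to compound 4. The estimate for compound 4 is 200000 nM, between 100000 nM and 500000 nM.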

Compound 4, half-maximal inhibitory concentration: > 100000 nM
Compound 4: no number, only a limit; the forecaster's own chance of this, stated with the estimate: 85%; the middle value is on the limit's open side.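

In this assay compound 4 gives > 100000 nM, a limit and not a number. Compound 3 gives > 100000 nM, also a limit, so no step can be read between compound 3 and compound 4: the limit of > 100000 nM in this assay, at which 3 of the 4 values shown sit. The compounds shown leave open whether nitro in place of hydrogen changes the value on the core of compound 3.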